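This account rests on a few compounds, and the source may have more. Where it says the series, first, only, none or still open, it means among the compounds named here.

Working notes on the series. Compound 1 `O=C1COc2ccccc2N1CCCn1cc(-c2ccccc2)nn1` is the reference point: in a functional assay on HeLa cells (Homo sapiens) for antiproliferative activity, read by sulforhodamine B assay, with a stated time of 48 h (on this read-out higher numbers stand for weaker inhibition of growth and lower numbers for stronger inhibition of growth), compound 1 gives 9000 nM, the only number shown so far. Compound 2 `O=C1COc2ccccc2N1CCCn1cc(-c2cccnc2)nn1` returns only a limit in this assay, reported as > 100000 nM, at which one of the two values sits (the limit of > 100000 nM in this assay, at which 1 of the 2 values shown sits). For the measured compounds named here, the step of an at least 11-fold higher number from compound 1 to compound 2 (1.04 log units; beyond the scatter) is therefore the single measured change on the group attached to the five-membered aromatic ring with three nitrogens, and it was large and toward weaker inhibition of growth.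

Compound 3 `CCCc1cn(CCCN2C(=O)COc3ccccc32)nn1` alters the same position: propyl in place of phenyl on an aromatic carbon. Going by the values given here, no step exactly like this has been measured; the one measured step at this position, from phenyl to pyridin-3-yl, already cost potency heavily, and removing the ring altogether for propyl is a more sweeping change. Compound 3 is therefore expected to show weaker inhibition of growth, with an estimated step of a 4.4-fold higher number from compound 1 to compound 3 (0.65 log units; beyond the scatter). The estimated value for compound 3 is 40000 nM, in the range 9000 nM to 150000 nM, with a real chance that only a limit is recorded.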

Compound 3, concentration for 50% growth inhibition: 23200 nM
For compound 3 the middle estimate is 1.7-fold (0.24 log units) above the measured one; measured number inside the range.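

Replacing phenyl with propyl on this aromatic carbon gives a 2.6-fold higher number from compound 1 to compound 3 (0.41 log units; beyond the scatter) in this assay, so a six-membered aromatic ring here is not required for a measurable number, although compound 1 keeps the lower value. The change from pyridin-3-yl to propyl gives an at least 4.3-fold lower number from compound 2 to compound 3 (0.63 log units; beyond the scatter), and among the three groups shown, pyridin-3-yl is therefore the least tolerated. Compound 2 is recorded only as a limit, so this second step gives a minimum size and not an exact one: the limit of > 100000 nM in this assay, at which 1 of the 3 values shown sits.

On these data alone, it remains open whether a longer chain, a branched chain such as isopropyl, or an amine at the end of the propyl chain would match or improve on phenyl. With a single chain shown, the compounds give no trend with chain length at this position.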